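The source may report more compounds than this note shows. Statements on the series, on what has been measured and on what is new or still open speak of the compounds shown alone.

Compound 1 `CCOc1cc(-c2ccccc2)nc2ccccc12`: > 10 ug/mL (a limit)
Compound 2 `Oc1cc(-c2ccccc2)nc2cc(F)ccc12`: 0.96 ug/mL
Compound 3 `COc1ccc2nc(-c3ccccc3)cc(O)c2c1`: 0.19 ug/mL

In a functional assay on A549 cells (Homo sapiens) for cytotoxicity (a higher number here means that more compound is needed for the effect, a lower number that less compound is needed), compound 1 has no exact number, and its > 10 ug/mL is only a limit of the assay. Compound 4 `CCCCOc1cc(-c2ccccc2)nc2ccccc12` keeps the core of compound 1 but turns ethoxy into butoxy: ethyl in place of hydrogen on a saturated chain carbon, two bonds along the chain from an oxygen on an aromatic ring. Among the measured compounds shown here, no measured pair shows what this longer chain does, so the expectation rests mainly on compound 1, whose > 10 ug/mL is the nearest guide. The expected step of a number no higher from compound 1 to compound 4 (the limit leaves the size open) is none beyond the usual scatter, and compound 4 may well also reach only the limit. For compound 4 the estimated value is 10 ug/mL, with an expected range from 3 ug/mL to 30 ug/mL.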

Compound 4, half-maximal effective concentration: > 10 ug/mL
Compound 4: a limit, no number; the forecaster's own chance of this, stated with the estimate: 65%; the middle value sits exactly at the limit.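

Compound 1 and compound 4 each give only a limit, so no step between them can be read: the limit of > 10 ug/mL in this assay, at which 2 of the 4 values shown sit.

The compounds shown leave open how far ethoxy and butoxy differ, if at all, in the amount of compound needed for the effect.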